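Moving from an ethylsulfonyl amide to a cyanomethyl-substituted sulfonamide

The compounds below may be only part of what the source reports. "The series", "measured", "known", "first", "only" and "open" are said of these compounds alone.

Measured so far:
compound 1 `CC1CCN(c2nc(C(F)(F)F)ccc2CNC(=O)C(C)c2ccc(NS(C)(=O)=O)cc2)CC1` — 1.2 nM
compound 2 `CC1CCN(c2nc(C(F)(F)F)ccc2CNC(=O)C(C)c2cc(F)c(NS(C)(=O)=O)c(Br)c2)CC1` — 0.7 nM
compound 3 `CCS(=O)(=O)Nc1ccc(C(C)C(=O)NCc2ccc(C(F)(F)F)nc2N2CCC(C)CC2)cc1F` — 4.4 nM

Of the compounds shown here, three sharing one core have been tested in an assay on cells for antagonist activity at transient receptor potential cation channel subfamily V member 1 (Homo sapiens), read by FLIPR and calcium flux, with a stated time of 15 min; a lower number here means a stronger inhibitor, a higher number a weaker inhibitor. Compound 1 gives 1.2 nM and compound 2 gives 0.7 nM, both of them beyond the scatter from compound 3, which gives 4.4 nM. Compound 3 therefore carries the highest number of the three, and the gap to its nearest neighbour, compound 1, is larger than the usual spread of repeats.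

Compound 4 `CC1CCN(c2nc(C(F)(F)F)ccc2CNC(=O)C(C)c2ccc(N(CC#N)S(C)(=O)=O)c(F)c2)CC1` has not yet been measured. It differs from compound 3 in one place, on an aromatic carbon of a six-membered aromatic ring of carbon only: (cyanomethyl)(methylsulfonyl)amino in place of (ethylsulfonyl)amino on an aromatic carbon. The group that enters carries 0 hydrogen-bond donors where the group that leaves carried 1.

Among the measured compounds shown here, no pair of measured compounds separated by a single change exists here, so the size of this step cannot be read from the data. Compound 4 is expected to show a step of a 1.3-fold higher number from compound 3 to compound 4 (0.10 log units; within the scatter) in this assay, roughly within the scatter, with the number slightly more likely to rise than to fall. For compound 4 the estimate is 5.5 nM, with a range from 1.2 nM to 25 nM.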

Compound 4, inhibition constant: "not active" (no number reported)
For compound 4 the study gives words and no number, and the estimate cannot be compared.
By their numbers in this assay, from the lowest: compounds 2 and 1 (each within the scatter of the next); then compound 3.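

Among the compounds shown here, compound 4 is reported in this assay as not active, with no number, so no step from compound 3 to compound 4 can be read. The compounds shown leave open which part of the change from (ethylsulfonyl)amino to (cyanomethyl)(methylsulfonyl)amino goes with this result. No other data shown bear on this result.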